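Fluoro on the shared core: from compound 3 to compound 4

A few compounds are considered here, and "the series" means these few. Any claim that something is new, unique, unknown or untested is made for them only; others in the source may bear on it.

Measured so far in a functional assay on HCT-116 cells (Homo sapiens) for antiproliferative activity, read by MTT assay, with a stated time of 48 h; a lower number here means a stronger inhibitor, a higher number a weaker inhibitor:
compound 1 `Cc1cnc(Nc2ccc(S(C)(=O)=O)cc2)nc1Nc1nc2ccccc2s1` gives 760 nM
compound 2 `Cc1ccc2nc(Nc3nc(Nc4ccc(S(C)(=O)=O)cc4)ncc3F)sc2c1` gives 9180 nM
compound 3 `CS(=O)(=O)c1ccc(Nc2nccc(Nc3nc4ccc(F)cc4s3)n2)cc1` gives 860 nM

Compound 3 stands second highest of the three numbers. Its nearest neighbour is compound 1, and that gap lies within the scatter, so no order between the two can be read. Compound 2 is furthest from it, with a gap well beyond the scatter. For the measured compounds named here, no two of the measured compounds differ in one place only, so no single-change step is available in this assay.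

Compound 4 `CS(=O)(=O)c1ccc(Nc2ncc(F)c(Nc3nc4ccc(F)cc4s3)n2)cc1` is compound 3 with fluoro in place of hydrogen on an aromatic carbon of the six-membered aromatic ring with 2 nitrogen, two atoms from the ring nitrogen, ortho to a large group and para to a large group. Compound 2 carries fluoro at this same place but differs from compound 3 in a second place as well, so its number cannot be laid on this change alone. Some weakening is nevertheless expected, because compound 2 gives 9180 nM while compound 3 gives 860 nM. The step from compound 3 to compound 4 is estimated at a 2.6-fold higher number from compound 3 to compound 4 (0.41 log units; beyond the scatter), toward a weaker inhibitor, with a range that still reaches into the scatter. Compound 4 is expected to give 2200 nM, between 700 nM and 7000 nM.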

Compound 4, half-maximal inhibitory concentration: > 50000 nM
Compound 4 ended at the assay's limit; the forecaster's own chance of this, stated with the estimate: 3%; middle value at least 22-fold (1.35 log units) from the limit.
By their numbers in this assay, from the lowest: compounds 1 and 3 (each within the scatter of the next); then compound 2. At a limit, above all of these: compound 4.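

Compound 4 reads in this assay as a limit and not as a number: the limit of > 50000 nM in this assay, at which 1 of the 4 values shown sits.

On the shared core, the change of fluoro in place of hydrogen on an aromatic carbon, ortho to a large group and para to a large group, now stands alone and gives a large step, an at least 58-fold higher number from compound 3 to compound 4 (1.76 log units; beyond the scatter); compound 2 carries fluoro at the same place but could not isolate this change. The second single change, fluoro in place of methyl on an aromatic carbon, gives an at least 5.4-fold higher number from compound 2 to compound 4 (0.73 log units; beyond the scatter), so with fluoro held at the first place, the outcome in this series also depends on the group at the second place.

The compounds shown do not tell whether the loss is specific to fluoro or follows from any group at this place, since compound 1, which carries methyl there, also differs from compound 3 in a second place. Chloro, an amine or a nitrile at this place, set on the core of compound 3, would separate these two readings.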